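Taking the sulfonyl out of compound 3

The source may hold more compounds than are shown below. What is called first, only, known or untested is meant among the compounds shown, and "the series" means these compounds.

Compound 1 `COC(=O)/C=C/C(=O)N[C@@H](C)Cn1ccc(-c2ccc(C#N)c(Cl)c2)n1`: 5230 nM
Compound 2 `CC(=O)c1ccc(S(=O)(=O)N[C@@H](C)Cn2ccc(-c3ccc(C#N)c(Cl)c3)n2)cc1`: 3950 nM
Compound 3 `C[C@@H](Cn1ccc(-c2ccc(C#N)c(Cl)c2)n1)NS(=O)(=O)c1cccnc1`: 2450 nM

All three were tested in a functional assay on VCaP cells (Homo sapiens) for antiproliferative activity, read by CCK-8 assay, with a stated time of 6 days; a higher number here means a weaker inhibitor, a lower number a stronger inhibitor. Compound 3 stands clear of compound 1 but not of compound 2. The unmeasured compound 4 `C[C@@H](Cn1ccc(-c2ccc(C#N)c(Cl)c2)n1)Nc1cccnc1` carries pyridin-3-yl in place of (pyridin-3-yl)sulfonyl on an amine nitrogen. Two measured steps offer indirect guidance: a 2.1-fold lower number from compound 1 to compound 3 (0.33 log units; beyond the scatter) and a 1.6-fold lower number from compound 2 to compound 3 (0.21 log units; within the scatter). Both are small, but neither puts pyridin-3-yl directly on the amine nitrogen, so the guide is weak. In this assay, no step beyond the scatter is expected, with a slightly higher number somewhat more likely. The expected change is a 1.4-fold higher number from compound 3 to compound 4 (0.15 log units; within the scatter). Compound 4 is estimated at 3500 nM, with an expected range of 1400 nM to 9000 nM.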

Compound 4, half-maximal inhibitory concentration: > 30000 nM
Compound 4: only a limit was reported (the forecaster's own chance of this, stated with the estimate: 10%); middle value at least 8.5-fold (0.93 log units) away from the limit.
By their numbers in this assay, from the lowest: compounds 3, 2 and 1 (each within the scatter of the next, the first and the last beyond it). At a limit, above all of these: compound 4.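

In this assay, compound 4 gives only a limit of the assay, not a number: the limit of > 30000 nM in this assay, at which 1 of the 4 values shown sits.

Losing the sulfonyl from this amine nitrogen brings an at least 12-fold higher number from compound 3 to compound 4 (1.08 log units; beyond the scatter), so pyridin-3-yl alone does not keep the activity of compound 3. The other comparison gives an at least 5.7-fold higher number from compound 1 to compound 4 (0.75 log units; beyond the scatter). Thus a sulfonyl or carbonyl link on this nitrogen appears to matter far more than the earlier exchanges between such linked groups suggested.

Going by these compounds, it remains open whether the link suffices by itself: a methanesulfonyl or acetyl group on this nitrogen, with no ring attached, would separate the link from the pyridin-3-yl ring.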